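From Chloro to Methoxy in a Cytotoxicity Series

This account rests on a few compounds, and the source may have more. Where it says the series, first, only, none or still open, it means among the compounds named here.

Compound 3 `COc1c(/C=C2/C(=O)Nc3ccc(Cl)cc32)c2ccccc2n1-c1ccccc1` gives 8910 nM in a functional assay on cells (Leukemia cell, Homo sapiens) for cytotoxicity, with a stated time of 48 h (on this read-out higher numbers stand for weaker inhibition of growth and lower numbers for stronger inhibition of growth), the second highest of three numbers: compound 2 `COc1c(/C=C2/C(=O)Nc3ccccc32)c2ccccc2n1-c1ccccc1` gives 2630 nM, and compound 1 `COc1cc2c(/C=C3/C(=O)Nc4ccc(O)cc43)c(Cl)n(Cc3cc(OC)c(OC)c(OC)c3)c2cc1C` gives 18600 nM. Among the measured compounds shown here, the single measured step in this set, a 3.4-fold higher number from compound 2 to compound 3 (0.53 log units; beyond the scatter), shows chloro in place of hydrogen on an aromatic carbon raising the number modestly. Compound 4 `COc1ccc2c(c1)/C(=C\c1c(OC)n(-c3ccccc3)c3ccccc13)C(=O)N2` carries methoxy in place of chloro on an aromatic carbon — methoxy in place of chloro on an aromatic carbon, meta to a fused ring and para to a fused ring. For the measured compounds named here, no measured step bears directly on methoxy at this place; the only comparison available is the chloro-for-hydrogen step, which was modest. The step expected for compound 4 is therefore small, a 1.8-fold lower number from compound 3 to compound 4 (0.25 log units; within the scatter), downward. Compound 4 is expected to give 5000 nM, within a range from 1500 nM to 15000 nM.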

Compound 4, concentration for total growth inhibition: 4470 nM
For compound 4 the middle estimate is 1.1-fold (0.05 log units) above the measured one; the measured number falls inside the stated range.
By their numbers in this assay, from the lowest: compounds 2, 4 and 3 (each within the scatter of the next, the first and the last beyond it); then compound 1.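

In this assay the place also takes methoxy, and the step for methoxy in place of chloro is a 2.0-fold lower number from compound 3 to compound 4 (0.30 log units; within the scatter) while that for methoxy in place of hydrogen is a 1.7-fold higher number from compound 2 to compound 4 (0.23 log units; within the scatter) and neither exceeds the scatter. Compound 4 thus stands within the scatter of both compound 2 and compound 3, although only chloro in place of hydrogen, a 3.4-fold higher number from compound 2 to compound 3 (0.53 log units; beyond the scatter), was beyond it. No evidence here accounts for these steps. The compounds shown leave open how an amine, a carboxylic acid or a longer chain such as ethoxy would read at this place.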